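What a Nitro Group May Do to Compound 3

The compounds below may be only part of what the source reports. "The series", "measured", "known", "first", "only" and "open" are said of these compounds alone.

In a functional assay on NCI-H460 cells (Homo sapiens) for inhibition, read by MTT assay, with a stated time of 24 h, tested at 100 ug/mL (a higher number here means more inhibition of growth at the concentration tested, a lower number less inhibition of growth), compound 3 `O=C(CCCCC(S)CCS)Nc1cccc(C(F)(F)F)c1` stands lowest of the three measured compounds, at 32.1%. Compound 2 `O=C(CCCCC1CCSS1)Nc1ccc([N+](=O)[O-])c(C(F)(F)F)c1` gives 51.7% and compound 1 `O=C(CCCCC1CCSS1)Nc1cccc(C(F)(F)F)c1` gives 68.8%, both beyond the scatter from it. Compound 4 `O=C(CCCCC(S)CCS)Nc1ccc([N+](=O)[O-])c(C(F)(F)F)c1` carries one change from compound 3: nitro in place of hydrogen on an aromatic carbon. The nitro sits ortho to a trifluoromethyl group and para to a large group. The same swap has one measured precedent, a number 17.1 percentage points lower from compound 1 to compound 2 (beyond the scatter). The other measured step, a number 36.7 percentage points lower from compound 1 to compound 3 (beyond the scatter), involves the sulfur-bearing group rather than the nitro, so it bears on the starting point only. A drop of similar size is expected here, although it rests on a single example. The expected step is a number 15.1 percentage points lower from compound 3 to compound 4 (beyond the scatter). The estimate for compound 4 is 17%, with an expected range from 5% to 32%.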

Compound 4, percent growth inhibition at one concentration: 95.9%
For compound 4 the middle estimate is 78.9 percentage points below the measured one; measured number above the stated range.
By their numbers in this assay, from the lowest: compound 3; then compound 2; then compound 1; then compound 4.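

Nitro in place of hydrogen on this aromatic carbon has no single effect that carries from one core to another; with the open-chain sulfur group it gives a number 63.8 percentage points higher from compound 3 to compound 4 (beyond the scatter), the opposite direction to its one precedent: the same change on two cores in this assay, a number 17.1 percentage points lower (beyond the scatter) from compound 1 to compound 2 and a number 63.8 percentage points higher (beyond the scatter) from compound 3 to compound 4, 80.9 percentage points apart, beyond the scatter of two such steps

Opening the sulfur ring reverses in the same way, giving a number 44.2 percentage points higher from compound 2 to compound 4 (beyond the scatter), so the two changes do not simply add up: the same change on two cores in this assay, a number 36.7 percentage points lower (beyond the scatter) from compound 1 to compound 3 and a number 44.2 percentage points higher (beyond the scatter) from compound 2 to compound 4, 80.9 percentage points apart, beyond the scatter of two such steps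

The compounds shown do not tell whether this rise is special to nitro. An amine or a nitrile on the same aromatic carbon of the open-chain core would test that.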